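Cyclic amidine ring size in the amide side chain

The compounds below may be only part of what the source reports. "The series", "measured", "known", "first", "only" and "open" are said of these compounds alone.

Measured compounds:
compound 1 `O=C(O)CC1CC(CNC(=O)CCNCc2ccccn2)=CCc2ccccc21`: 2700 nM
compound 2 `O=C(O)CC1CC(CNC(=O)CCCc2ccc3c(n2)NCCC3)=CCc2ccccc21`: 6.9 nM
compound 3 `O=C(O)CC1CC(CNC(=O)CCCNC2=NCCN2)=CCc2ccccc21`: 18 nM

In a functional assay on IGROV-1 cells (Homo sapiens) for inhibition (a higher number here means a weaker inhibitor, a lower number a stronger inhibitor), compound 3 stands second highest of the three numbers. Its nearest neighbour is compound 2, reached by a 2.6-fold higher number from compound 2 to compound 3 (0.42 log units; beyond the scatter); the furthest is compound 1, from which a 150-fold lower number from compound 1 to compound 3 (2.18 log units; beyond the scatter) leads to compound 3. Both steps exchange the whole terminal group at the end of the chain, and both lie beyond the scatter, so this part of the molecule is where the numbers in this assay move most.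

Compound 4 `O=C(O)CC1CC(CNC(=O)CCCNC2=NCCCN2)=CCc2ccccc21` is the unmeasured partner of compound 3. The change is a group of 6 heavy atoms (4 carbon, 2 nitrogen; one six-membered non-aromatic ring with 2 hetero atoms) in place of a group of 5 heavy atoms (3 carbon, 2 nitrogen; one five-membered non-aromatic ring with 2 hetero atoms), on an amine nitrogen. Neither measured step is a ring-size change of this kind; the step from compound 2 to compound 3 replaces a larger bicyclic group, and the step from compound 1 to compound 3 replaces an aromatic one. A change of a single ring atom in an otherwise unchanged group is far smaller than either, so only a small step is expected, if any, and the direction is uncertain; a slight lowering is thought somewhat more likely given that compound 2 gives 6.9 nM with a six-membered ring at the same end of the chain. The step expected is a 2.0-fold lower number from compound 3 to compound 4 (0.30 log units; within the scatter). Compound 4 is therefore estimated at 9 nM, with a range from 3 nM to 30 nM.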

Compound 4, half-maximal inhibitory concentration: 2.7 nM
Beside the measured number, compound 4's estimate is 3.3-fold (0.52 log units) above it, outside the stated range (below it).
By their numbers in this assay, from the lowest: compound 4; then compound 2; then compound 3; then compound 1.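

In this assay, one added ring atom is enough to give a step beyond the scatter, a 6.7-fold lower number from compound 3 to compound 4 (0.82 log units; beyond the scatter), so the size of this ring on the amine nitrogen matters, and not only the wholesale exchange of the terminal group seen earlier. The bicyclic terminal group no longer gives the lowest number, with a 2.6-fold lower number from compound 2 to compound 4 (0.41 log units; beyond the scatter) as the printed step, and the span at this end of the chain widens, with a 1000-fold lower number from compound 1 to compound 4 (3.00 log units; beyond the scatter) as its largest step. Nothing measured here explains why the six-membered ring gives the lower number.

Only the five-membered and six-membered rings can be compared directly, so two sizes fix no trend, and a seven-membered ring in the same place, or a methyl group on the ring nitrogen, would show whether the lowering continues or is lost. Also open is whether the six-membered ring keeps its advantage over the five-membered ring on a longer or shorter chain, since both rings are shown on one chain only.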